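Shifting a Methyl Group on a Weak Receptor Modulator

The source may report more compounds than this note shows. Statements on the series, on what has been measured and on what is new or still open speak of the compounds shown alone.

Compound 1 `Cc1cc(C(=O)O)ccc1OCCCCOc1ccc(C(=O)CC(C)C)c(O)c1C` was tested in an assay on HEK293 cells for positive allosteric modulation of metabotropic glutamate receptor 3 (Rattus norvegicus), read by thallium flux, with a stated time of 2.5 min (on this read-out lower numbers stand for an effect already at smaller amounts and higher numbers for an effect only at larger amounts of compound), and gives 1850 nM. Compound 2 `Cc1cc(OCCCCOc2ccc(C(=O)CC(C)C)c(O)c2C)ccc1C(=O)O` gives 3910 nM in this assay. The two differ only as 4-carboxy-3-methylphenyl in place of 4-carboxy-2-methylphenyl on an oxygen on a saturated carbon, and the step between them is a 2.1-fold higher number from compound 1 to compound 2 (0.33 log units; beyond the scatter). Compound 3 `Cc1cc(C(=O)O)ccc1OCCCCOc1ccc(C(=O)CC2CCCC2)c(O)c1C` has a different core, differing from compound 1 as cyclopentyl in place of isopropyl on a saturated chain carbon bound to a carbonyl carbon; that step is an at least 5.4-fold higher number from compound 1 to compound 3 (0.73 log units; beyond the scatter). In this assay compound 3 reaches only a limit of the assay, > 10000 nM, in line with the limit of > 10000 nM in this assay, at which 1 of the 3 values shown sits. Compound 4 `Cc1cc(OCCCCOc2ccc(C(=O)CC3CCCC3)c(O)c2C)ccc1C(=O)O` has not yet been measured. It differs from compound 3 as 4-carboxy-3-methylphenyl in place of 4-carboxy-2-methylphenyl on an oxygen on a saturated carbon, which is the same change that turns compound 1 into compound 2, now made on the core of compound 3. That earlier change gave a higher number, and the number would be expected to rise in the same direction here. Because compound 3 already sits at the limit (the limit of > 10000 nM in this assay, at which 1 of the 3 values shown sits), compound 4 is expected to give around 20000 nM, most likely between 8000 nM and 60000 nM, and quite probably again only a limit. The expected step for compound 4 is a step that the limit leaves unreadable from compound 3 to compound 4, resting on a 2.1-fold higher number from compound 1 to compound 2 (0.33 log units; beyond the scatter).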

Compound 4, half-maximal effective concentration: > 10000 nM
Compound 4 was reported as a limit; the forecaster's own chance of this, stated with the estimate: 85%; the middle value is on the limit's open side.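

In this assay compound 4 gives > 10000 nM, which is a limit of the assay and not a number, so the effect of swapping 4-carboxy-2-methylphenyl for 4-carboxy-3-methylphenyl on the core of compound 3 cannot be read. The change from isopropyl to cyclopentyl can be read on both cores, and with an at least 2.5-fold higher number from compound 2 to compound 4 (0.40 log units; beyond the scatter) it points the same way on each: the same change on two cores in this assay, an at least 5.4-fold higher number (0.73 log units; beyond the scatter) from compound 1 to compound 3 and an at least 2.5-fold higher number (0.40 log units; beyond the scatter) from compound 2 to compound 4; the limit leaves it open whether they differ. This shows that the direction of the cyclopentyl change carries from one core to the other, but it does not show that the size carries too, and it does not show whether the methyl shift carries over, since compound 3 and compound 4 stop at the same limit: the limit of > 10000 nM in this assay, at which 2 of the 4 values shown sit.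

The compounds shown leave open how far beyond the limit compound 3 and compound 4 lie. They also leave open whether a cyclobutyl group in place of the isopropyl, or a tetrazole in place of the carboxylic acid, would give a readable number on these cores.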